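Swapping Chloro for Methoxy on a Weak Binder

A few compounds are considered here, and "the series" means these few. Any claim that something is new, unique, unknown or untested is made for them only; others in the source may bear on it.

Measured so far in an assay on CHO cells for displacement of a labelled ligand from adenosine receptor A3 (Homo sapiens), read by scintillation counting, with a stated time of 60 min; on this read-out lower numbers stand for stronger inhibition and higher numbers for weaker inhibition:
compound 1, `O=C(C/C=C/c1ccccc1)Nc1nc2ccccc2c(=O)s1`, gives 158 nM
compound 2, `O=C(C/C=C/c1cccc(Cl)c1)Nc1nc2ccccc2c(=O)s1`, gives > 1000 nM
compound 3, `O=C(CCc1ccccc1Br)Nc1nc2ccccc2c(=O)s1`, gives > 1000 nM

Compound 2 stands at the weak end of these three. Its value of > 1000 nM is a limit of this assay and not a number. The same holds for compound 3, whose value of > 1000 nM is also a limit. On these data alone, only compound 1 yields a real number, and the step of an at least 6.3-fold higher number from compound 1 to compound 2 (0.80 log units; beyond the scatter) shows that chloro in place of hydrogen on an aromatic carbon costs binding, although how much beyond the limit is unknown, as the limit of > 1000 nM in this assay, at which 2 of the 3 values shown sit, shows.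

Compound 4, `COc1cccc(/C=C/CC(=O)Nc2nc3ccccc3c(=O)s2)c1`, changes compound 2 by methoxy in place of chloro on an aromatic carbon, so that 3-chlorophenyl becomes 3-methoxyphenyl. Among the measured compounds shown here, no measured step here involves methoxy, so the only guide is that removing the chloro returns toward compound 1. Compound 4 is therefore expected to show a step of an at least 1.4-fold lower number from compound 2 to compound 4 (0.15 log units; that floor lies within the scatter), toward stronger binding but likely not back to the level of compound 1. The estimate for compound 4 in this assay is 700 nM, within 200 nM to 3000 nM.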

Compound 4, inhibition constant: 115 nM
Compound 4: middle estimate off by 6.1-fold (0.78 log units), on the high side, and the stated range ends above it.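

Going from 3-chlorophenyl to 3-methoxyphenyl gives an at least 8.6-fold lower number from compound 2 to compound 4 (0.93 log units; beyond the scatter), so a group on this aromatic carbon does not always cost binding, as compound 2 alone had suggested. The value of compound 2 is a limit and not a number, so the size of that step is only a floor: the limit of > 1000 nM in this assay, at which 2 of the 4 values shown sit. Methoxy in place of hydrogen gives a 1.4-fold lower number from compound 1 to compound 4 (0.14 log units; within the scatter), so the shared core with its chain keeps its binding with methoxy on this carbon, and the two compounds cannot be told apart.

On these data alone, with only hydrogen, chloro and methoxy compared at this place, it remains open how an amine, a hydroxyl or a methyl there would compare. Also open, as far as these compounds go, is whether a longer chain carrying the 3-methoxyphenyl ring would keep the binding of compound 4.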